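The source may report more compounds than this note shows. Statements on the series, on what has been measured and on what is new or still open speak of the compounds shown alone.

Working notes on a small set of piperazine-linked amides tested in an assay on cells for agonist activity at D(4) dopamine receptor (Homo sapiens), read by luminescence and beta-arrestin recruitment, with a stated time of 90 min; a higher number here means a larger maximal response, a lower number a smaller maximal response.

Going by the values given here, compound 1 `O=C(CN1CCN(c2ccccn2)CC1)Nc1cccnc1` is the one member of the set with a number: in this assay compound 1 gives 19%. Compound 2 `CCc1cccc(NC(=O)CN2CCN(c3ccc(Cl)cn3)CC2)c1`, which carries a chloro on its pyridine and an ethylphenyl amide, is recorded in this assay as "not active" (no number reported). Compound 3 `O=C(CN1CCN(c2ccccn2)CC1)Nc1cncnc1`, the pyrimidinyl amide with the unsubstituted pyridinyl piperazine, is likewise recorded in this assay as "not active" (no number reported); no maximal response is given for it, so it stands below anything that could be compared with compound 1. Among the compounds with values here, no pair in the measured set differs at a single place, so no step size is available.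

Compound 4 `O=C(CN1CCN(c2ccc(Cl)cn2)CC1)Nc1cncnc1` is compound 3 with one alteration: chloro in place of hydrogen on an aromatic carbon. The chloro enters on an aromatic carbon two atoms from the ring nitrogen, giving 5-chloropyridin-2-yl where pyridin-2-yl stood. Within the data shown here, compound 2, the only other chloro-bearing member, is also inactive, and compound 3 itself gives no number, so nothing in the set supports a rise beyond the scatter; a small or absent response is what is expected. For compound 4 the maximal response in this assay is estimated at 10%, within 0% to 25%, with a real chance that only "not active" is reported.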

Compound 4, largest response reached (Emax), in percent of the reference or control that the assay uses: "not active" (no number reported)
Nothing numeric was reported for compound 4; no gap can be computed for the estimate.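

With compound 3 and compound 4 both recorded without a number in this assay, no step can be read for the change from pyridin-2-yl to 5-chloropyridin-2-yl. The compounds shown leave open whether chloro at this place would alter the maximal response of a compound with a measurable one, such as compound 1. No available evidence bears on this result.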